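Oxanylamino in place of 4-aminopiperidinyl: solubility

The source may report more compounds than this note shows. Statements on the series, on what has been measured and on what is new or still open speak of the compounds shown alone.

Compound 3 `CNc1nc(N2CCC(N)CC2)c2sc(-c3ccc(C(F)(F)F)cc3)cc2n1` stands in a physicochemical assay for solubility, at pH 2 (on this read-out higher numbers stand for higher solubility and lower numbers for lower solubility), only at a limit, > 200 ug/mL, namely (the limit of > 200 ug/mL in this assay, at which 1 of the 3 values shown sits). Compound 1 `CNc1nc(NCCCN(C)C)c2sc(-c3ccc(C(F)(F)F)cc3)cc2n1` gives 240 ug/mL in this assay. Compound 2 `CNc1nc(N)c2sc(-c3ccc(C(F)(F)F)cc3)cc2n1` gives only a limit, > 100 ug/mL. Both steps that reach compound 3 are therefore unreadable in size: a step that the limit leaves unreadable from compound 1 to compound 3 and a step that the two limits leave unreadable from compound 2 to compound 3. Compound 4 `CNc1nc(NC2CCOCC2)c2sc(-c3ccc(C(F)(F)F)cc3)cc2n1` differs from compound 3 by (oxan-4-yl)amino in place of 4-aminopiperidin-1-yl on an aromatic carbon. Within the data shown here, no measured step covers this exchange, and the three values shown give no readable direction beyond the scatter, so the expectation rests on the structural change alone. The step of an at least 3.3-fold lower number from compound 3 to compound 4 (0.52 log units; beyond the scatter) is an estimate. Compound 4 is expected at 60 ug/mL, with a range from 10 ug/mL to 250 ug/mL.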

Compound 4, solubility: < 5 ug/mL
Compound 4: no number, only a limit; the forecaster's own chance of this, stated with the estimate: 25%; middle value at least 12-fold (1.07 log units) away from the limit.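

The steps among compound 1, compound 2 and compound 3 cannot be read, but in this assay compound 4 gives large ones: an at least 40-fold lower number from compound 3 to compound 4 (1.60 log units; beyond the scatter), an at least 20-fold lower number from compound 2 to compound 4 (1.30 log units; beyond the scatter) and an at least 48-fold lower number from compound 1 to compound 4 (1.68 log units; beyond the scatter). Compound 4 stands at a limit: the limit of < 5 ug/mL in this assay, at which 1 of the 4 values shown sits. At this aromatic carbon, next to the ring nitrogen, (oxan-4-yl)amino and 4-aminopiperidin-1-yl are thus far from interchangeable, though both carry one six-membered non-aromatic ring and match in heavy atoms, donors and acceptors.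

The compounds shown leave open whether the oxygen of the oxane ring or the ring attachment through nitrogen sets this step. A piperidin-4-ylamino group, which keeps the linking nitrogen of compound 4 and has a ring nitrogen in place of its oxygen, would separate the two.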